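Nitro in place of bromo on compound 3

This account rests on a few compounds, and the source may have more. Where it says the series, first, only, none or still open, it means among the compounds named here.

In a functional assay on P388 cells (Mus musculus) for inhibition (a higher number here means a weaker inhibitor, a lower number a stronger inhibitor), compound 1 `COc1cccc(/C=C2\Cc3ccccc3C2=O)c1` gives > 50000 nM, and this value is a limit of the assay. Compound 2 `O=C1/C(=C/c2ccc(Br)cc2)CCc2ccccc21` gives 20400 nM. Compound 3 `O=C1/C(=C/c2cccc(Br)c2)CCCc2ccccc21` gives 10500 nM. The values of compound 2 and compound 3 lie within the scatter of each other, so compound 3 stands level with compound 2. Going by the values given here, these two are the only actual numbers so far.

Compound 4 `O=C1/C(=C/c2cccc([N+](=O)[O-])c2)CCCc2ccccc21` carries nitro in place of bromo on an aromatic carbon, meta to a large group: nitro in place of bromo on an aromatic carbon. Among the compounds with values here, the series offers no measured pair differing in one place, so this change has no direct precedent. The reference is compound 3 at 10500 nM, and no step beyond the scatter is expected in this assay, with neither direction favoured. The expected step, a 1.1-fold higher number from compound 3 to compound 4 (0.06 log units; within the scatter), stays small beside the wide uncertainty. For compound 4 the estimated value is 12000 nM, with an expected range of 4000 nM to 40000 nM.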

Compound 4, half-maximal inhibitory concentration: 15800 nM
For compound 4 the middle estimate is 1.3-fold (0.12 log units) below the measured one; the measured number falls inside the stated range.
By their numbers in this assay, from the lowest: compounds 3, 4 and 2 (each within the scatter of the next). At a limit, above all of these: compound 1.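

Going by these compounds alone, this is the first step between two compounds that differ in one place: in this assay, nitro in place of bromo on an aromatic carbon, meta to a large group, gives a 1.5-fold higher number from compound 3 to compound 4 (0.18 log units; within the scatter). This position therefore accepts nitro, with 3 heavy atoms and 2 hydrogen-bond acceptors, in place of bromo, with 1 heavy atom and 0 hydrogen-bond acceptors, without a step beyond the scatter. No measured property in hand bears on this comparison of the two groups.

Going by these compounds, whether any group on this aromatic carbon can move the number beyond the scatter remains open, and an amine or a carboxylic acid there would test it. Compound 2 and compound 3 differ in more than one place, so the placing of bromo cannot be separated from the other differences in the core.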